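Extending compound 1 with an (oxan-4-yl)methyl group

The source may hold more compounds than are shown below. What is called first, only, known or untested is meant among the compounds shown, and "the series" means these compounds.

Measured compounds:
compound 1 `CN(C)C(=O)CN1CCC(c2cc3c(-c4ccc(=O)n(C)c4)ccnc3[nH]2)CC1` — > 1000000 nM
compound 2 `COc1cc(F)ccc1-c1ccnc2[nH]c(C3CCN(CC(=O)N(C)C)CC3)cc12` — 38000 nM
compound 3 `COc1cc(F)ccc1-c1ccnc2[nH]c(C3CCOCC3)cc12` — 97000 nM

All three were tested in a physicochemical assay for solubility, in phosphate buffer, at pH 7.4; a higher number here means a more soluble compound, a lower number a less soluble compound. For compound 1 the reading > 1000000 nM is a limit of this assay rather than a number, namely the limit (the limit of > 1000000 nM in this assay, at which 1 of the 3 values shown sits); compound 1 therefore stands at the upper edge of what this assay reports. Compound 2 gives 38000 nM in this assay, and compound 3 gives 97000 nM there. Among the measured compounds shown here, the one step that joins two measured compounds, an at least 26-fold lower number from compound 1 to compound 2 (1.42 log units; beyond the scatter), exchanges the aromatic group attached to the shared core. Between compound 2 and compound 3 no single-point step is tabulated; their two values simply stand side by side.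

The compound still to be measured is compound 4 `CN(C)C(=O)CN1CCC(c2cc3c(-c4ccc(=O)n(CCC5CCOCC5)c4)ccnc3[nH]2)CC1`. Its difference from compound 1 is (oxan-4-yl)methyl in place of hydrogen on a saturated chain carbon bound to an aromatic nitrogen. For the measured compounds named here, none of the measured steps touches this position, so the change from compound 1 to compound 2 bears on it only in showing how far a single substituent swap can move this assay. The chain added in compound 4 is saturated and carries no charge, and compound 4 keeps the basic amine and the rest of compound 1 unchanged. It is therefore expected that the step of an at least 3.3-fold lower number from compound 1 to compound 4 (0.52 log units; beyond the scatter) will be a moderate decrease, possibly still within the scatter. Compound 4 is estimated at 300000 nM, in the range 60000 nM to 1000000 nM.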

Compound 4, solubility: 370000 nM
Compound 4: the middle estimate sits 1.2-fold (0.09 log units) below what was measured; measured number inside the range.
By their numbers in this assay, from the lowest: compound 2; then compound 3; then compound 4. At a limit, above all of these: compound 1.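

Among the compounds shown here, compound 4 gives the first reading for a change at this position, a saturated chain carbon bound to an aromatic nitrogen, and in this assay (oxan-4-yl)methyl in place of hydrogen appears as an at least 2.7-fold lower number from compound 1 to compound 4 (0.43 log units; beyond the scatter). For the compounds shown here, with the rest of compound 1 unchanged, this one addition is enough to bring the reading down from the upper edge of this assay to a measured number, so this position, which no earlier step touched, does register a change. For compound 1 the value > 1000000 nM is a limit, and the full size of the step stays unknown: the limit of > 1000000 nM in this assay, at which 1 of the 4 values shown sits.

The compounds shown leave open how much of the step belongs to the ring itself and how much to the chain that carries it, which a plain propyl chain or a cyclohexyl ring in place of the oxan-4-yl ring would help to separate. They also leave open whether a chain ending in an amine or a carboxylic acid at this same position would give a different reading in this assay.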